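Aryl group change on the ring amine nitrogen

The source may hold more compounds than are shown below. What is called first, only, known or untested is meant among the compounds shown, and "the series" means these compounds.

Three compounds of the series carry a measured value in an assay on HEK293 cells for inhibition of Voltage-dependent T-type calcium channel subunit alpha-1G (Homo sapiens), read by patch clamp; on this read-out higher numbers stand for weaker inhibition and lower numbers for stronger inhibition. Compound 1 `CCCc1nc(-c2ccccc2)c(CNCCN2CCN(C(c3ccccc3)c3ccccc3)CC2)o1` gives 7470 nM. Compound 2 `CCCc1nc(-c2ccccc2)c(CNCCN2CCN(c3ccc(Cl)cc3)CC2)o1` gives 2820 nM, the second highest of the three numbers. Compound 3 `CCCc1nc(-c2ccccc2)c(CNCCCN2CCN(c3cccc(Cl)c3)CC2)o1` gives 1750 nM; the numbers for compound 2 and compound 3 lie within the usual scatter of each other, so no order between them can be read. Compound 1 stands furthest from compound 2, with a higher number that lies beyond the scatter. Compound 4 `CCCc1nc(-c2ccccc2)c(CNCCN2CCN(c3cccc(F)c3)CC2)o1` has not been measured in this assay. It differs from compound 2 in one place: 3-fluorophenyl in place of 4-chlorophenyl on an amine nitrogen in a ring. For the measured compounds named here, no step between measured compounds that differ in only one place is available, so this change has no direct precedent; compound 3 differs from compound 2 in more than one place, and its value speaks only loosely to the change at hand. The expected step from compound 2 to compound 4 is a 1.2-fold higher number from compound 2 to compound 4 (0.09 log units; within the scatter), small and not in a clear direction beyond the scatter. For compound 4 the estimated value is 3500 nM, with a range from 1500 nM to 8000 nM.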

Compound 4, half-maximal inhibitory concentration: 3350 nM
Compound 4: middle estimate off by 1.0-fold (0.02 log units), on the high side, and the stated range covers the measured number.
By their numbers in this assay, from the lowest: compounds 3, 2 and 4 (each within the scatter of the next); then compound 1.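

In this assay, placing 3-fluorophenyl instead of 4-chlorophenyl on the amine nitrogen in the ring gives a 1.2-fold higher number from compound 2 to compound 4 (0.07 log units; within the scatter) and is the only step among the compounds shown that differs in one place. At this position, the halogen and its place on the phenyl can therefore change together without moving the number beyond the scatter, and no order can be read between the two compounds. No measured evidence bears on why this step is small.

The halogen and its place on the phenyl change together here, so this single pair cannot separate the two changes and says little about the position as a whole. As far as these compounds go, it also remains open whether unsubstituted phenyl, a methoxy-bearing phenyl, a nitrile-bearing phenyl or a pyridine ring on this nitrogen would stay within the scatter of these two compounds or move beyond it.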